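Side group change from compound 2 to compound 3

The source may hold more compounds than are shown below. What is called first, only, known or untested is meant among the compounds shown, and "the series" means these compounds.

Measured in a functional assay on HCT-116 cells (Homo sapiens) for cytotoxicity (a lower number here means a stronger inhibitor, a higher number a weaker inhibitor), as half-maximal inhibitory concentrations:
compound 1 `COc1cc(N2CCN(C(=O)C3CCC(O)CC3)CC2)ccc1Nc1nc(NC2CCCCC2)c2nc[nH]c2n1` gives 15 nM
compound 2 `COc1cc(N2CCN(C(=O)N3CCC(O)C3)CC2)ccc1Nc1nc(NC2CCCCC2)c2nc[nH]c2n1` gives 27 nM

Within the data shown here, the only measured step (a 1.8-fold higher number from compound 1 to compound 2 (0.26 log units; within the scatter)) stays within the scatter and places 3-hydroxypyrrolidin-1-yl in place of 4-hydroxycyclohexyl on a carbonyl carbon. Compound 2 therefore stands level with compound 1 on these numbers. Compound 3 `COc1cc(N2CCN(CC3CCOC3)CC2)ccc1Nc1nc(NC2CCCCC2)c2nc[nH]c2n1` carries (oxolan-3-yl)methyl in place of (3-hydroxypyrrolidin-1-yl)carbonyl on an amine nitrogen in a ring. Both measured compounds keep the carbonyl and compound 3 does not, so the measured step is only a loose guide. No step beyond the scatter is expected in this assay, and the estimated step is small (a 1.1-fold lower number from compound 2 to compound 3 (0.03 log units; within the scatter)). The estimate for compound 3 is 25 nM with a wide expected range (8 nM to 80 nM).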

Compound 3, half-maximal inhibitory concentration: 66 nM
For compound 3 the middle estimate is 2.6-fold (0.42 log units) below the measured one; the range from low to high includes it.
By their numbers in this assay, from the lowest: compounds 1 and 2 (each within the scatter of the next); then compound 3.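

In this assay, the position on the amine nitrogen of the six-membered ring now shows that it responds to the group placed there: compounds 1 and 2 stood within the scatter of each other, whereas (oxolan-3-yl)methyl gives a 2.4-fold higher number from compound 2 to compound 3 (0.39 log units; beyond the scatter) and a 4.4-fold higher number from compound 1 to compound 3 (0.64 log units; beyond the scatter). Both steps are modest, and the change removes the carbonyl and the hydroxyl together, so neither can be singled out as the source of the difference. Nothing measured here accounts for the step.

Going by these compounds, it remains open whether the carbonyl or the hydroxyl matters more; an (oxolan-3-yl)carbonyl group, which keeps the carbonyl without the hydroxyl, would separate the two. Also open, on these data alone, is how this position would respond to a carboxylic acid or a longer chain.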